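A few compounds are considered here, and "the series" means these few. Any claim that something is new, unique, unknown or untested is made for them only; others in the source may bear on it.

Compound 1 `COc1cc(C(=O)NS(=O)(=O)c2ccccc2C)ccc1Cc1cn(C)c2ccc(C(=O)NCC3CCCC3)cc12` gives 8.4 in an assay on isolated protein for binding affinity to cysteinyl leukotriene receptor 1 (Cavia porcellus); on this read-out lower numbers stand for lower potency and higher numbers for higher potency (the scale is a negative logarithm). Going by the values given here, its only measured neighbour is compound 2 `CCC(C)CNC(=O)c1ccc2c(c1)c(Cc1ccc(C(=O)NS(=O)(=O)c3ccccc3C)cc1OC)cn2C`, which in this assay gives 8.7; the step of a number 0.30 log units higher from compound 1 to compound 2 (within the scatter) keeps the two compounds within the scatter of each other. Compound 3 `CCCn1cc(Cc2ccc(C(=O)NS(=O)(=O)c3ccccc3C)cc2OC)c2cc(C(=O)NCC3CCCC3)ccc21` differs from compound 1 by ethyl in place of hydrogen on a saturated chain carbon bound to an aromatic nitrogen. No measured step touches the carbon bound to the aromatic nitrogen, so nothing shown speaks for a shift in this assay beyond the scatter. Compound 3 is therefore expected to give about 8.4, between 7.8 and 9, a step of no change at the digits printed from compound 1 to compound 3 (within the scatter) from compound 1.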

Compound 3, negative logarithm of the antagonist equilibrium constant: 8.7
Beside the measured number, compound 3's estimate is 0.30 log units below it; the range from low to high includes it.
By their numbers in this assay, from the lowest: compounds 1, 2 and 3 (each within the scatter of the next).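

In this assay, ethyl in place of hydrogen on the saturated chain carbon bound to the aromatic nitrogen gives a number 0.30 log units higher from compound 1 to compound 3 (within the scatter), so going from methyl to propyl at this place leaves the number within the scatter. Going by these compounds alone, this is the first measured change at this position. No evidence bears on this result. The compounds shown leave open whether a longer chain, an amine or a carboxylic acid on this carbon would also stay within the scatter. They also leave open how ethyl here would combine with sec-butyl in place of cyclopentyl.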